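Aryl variation on the shared core; sulfamoylphenyl next

A few compounds are considered here, and "the series" means these few. Any claim that something is new, unique, unknown or untested is made for them only; others in the source may bear on it.

Compound 3 `CCCS(=O)(=O)Nc1ccc(F)c(C(=O)c2n[nH]c3ncc(-c4ccc(OC)cc4Cl)cc23)c1F` holds the lowest of the three numbers in an assay for binding affinity to dual specificity mitogen-activated protein kinase kinase 4 (Homo sapiens), read by KINOMEscan, tested at 100 nM (on this read-out higher numbers stand for a weaker effect at the one concentration tested and lower numbers for a stronger effect), giving 5.3%; the nearest is compound 1 `CCCS(=O)(=O)Nc1ccc(F)c(C(=O)c2n[nH]c3ncc(-c4ccc(C)cc4)cc23)c1F`, which gives 5.4%, and compound 2 `CCCS(=O)(=O)Nc1ccc(F)c(C(=O)c2n[nH]c3ncc(-c4cccc(OC)c4)cc23)c1F` gives 6.3%. All gaps lie within the scatter: a number 0.1 percentage points lower from compound 1 to compound 3 (within the scatter), a number 1 percentage points lower from compound 2 to compound 3 (within the scatter), and likewise a number 0.9 percentage points higher from compound 1 to compound 2 (within the scatter). Compound 4 `CCCS(=O)(=O)Nc1ccc(F)c(C(=O)c2n[nH]c3ncc(-c4ccc(S(N)(=O)=O)cc4)cc23)c1F` is not yet measured. It differs from compound 3 in the group attached to the shared core: 4-sulfamoylphenyl in place of 2-chloro-4-methoxyphenyl on an aromatic carbon. Among the compounds with values here, the steps that bear on this change are the two that already swapped the same group, 4-methylphenyl for 2-chloro-4-methoxyphenyl and 3-methoxyphenyl for 2-chloro-4-methoxyphenyl, and neither moved the number beyond the scatter. Within the data shown here, the 4-sulfamoylphenyl group itself has no counterpart among the measured compounds, so the expectation rests only on the flatness of those steps. For compound 4 the expected step is a number 2.7 percentage points higher from compound 3 to compound 4 (within the scatter), with no change beyond the scatter foreseen. The estimate for compound 4 in this assay is 8%, expected to fall between 3% and 20%.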

Compound 4, a percentage reported as activity, at one concentration (the size of the read-out at that concentration, not a potency): 0.25%
Estimate against measurement, compound 4: 7.8 percentage points above, and the stated range ends above it.
By their numbers in this assay, from the lowest: compounds 4, 3, 1 and 2 (each within the scatter of the next).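

In this assay, the 4-sulfamoylphenyl group is the only group shown on this aromatic carbon with a hydrogen-bond donor, and it leaves the read-out within the scatter of all three earlier aryl groups (a number 5.1 percentage points lower from compound 3 to compound 4 (within the scatter); a number 6.1 percentage points lower from compound 2 to compound 4 (within the scatter); a number 5.2 percentage points lower from compound 1 to compound 4 (within the scatter)). The flat picture at this position, so far seen only across methyl, methoxy and chloro substitution, therefore extends to a sulfamoyl group, and no group shown stands apart from the others. Nothing shown here accounts for these steps.

Each number comes from one concentration, so any difference in potency among these four aryl groups remains open. Also open, going by these compounds, is whether a carboxylic acid, an amine or a longer chain in place of the sulfamoyl group would stay within the scatter.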